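Replacing a trimethylphenyl thioether on a nucleoside scaffold

The source may report more compounds than this note shows. Statements on the series, on what has been measured and on what is new or still open speak of the compounds shown alone.

Measured compounds:
compound 1 `CC(=O)c1ccccc1Sc1nc(N)nc2c1ncn2[C@@H]1O[C@H](CO)[C@@H](O)[C@H]1O` — 447000 nM
compound 2 `Cc1cc(C)c(SCc2ncnc3c2ncn3[C@@H]2O[C@H](CO)[C@@H](O)[C@H]2O)c(C)c1` — 33100 nM

In an assay on isolated protein for binding affinity to Equilibrative nucleoside transporter 1 (Homo sapiens) (on this read-out higher numbers stand for weaker inhibition and lower numbers for stronger inhibition), compound 1 gives 447000 nM, and compound 2 gives 33100 nM. Compound 2 thus holds the lower of the two numbers, and its gap to compound 1 lies beyond the usual scatter of this assay. Going by the values given here, the two compounds differ in several places at once, so their values show only that compound 2 inhibits more strongly; no single step between them can be singled out.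

Compound 3 `N#Cc1ccc(SCc2ncnc3c2ncn3[C@@H]2O[C@H](CO)[C@@H](O)[C@H]2O)cc1` is the next compound to be measured. It keeps the whole of compound 2 apart from one change, (4-cyanophenyl in place of 2,4,6-trimethylphenyl on a sulfur). Among the compounds with values here, no measured pair in this set isolates this kind of change, so the step is uncertain in both size and direction. Since compound 2 gives 33100 nM, a modest weakening toward a higher number is expected, with the estimated step of a 1.8-fold higher number from compound 2 to compound 3 (0.26 log units; within the scatter) likely close to the scatter. For compound 3 the expected value in this assay is 60000 nM, within a range from 12000 nM to 300000 nM.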

Compound 3, half-maximal inhibitory concentration: 81.3 nM
Compound 3: the middle estimate sits 740-fold (2.87 log units) above what was measured; the whole stated range lies above it.
By their numbers in this assay, from the lowest: compound 3; then compound 2; then compound 1.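

In this assay, going by these compounds alone, the single change from 2,4,6-trimethylphenyl to 4-cyanophenyl on a sulfur gives a 410-fold lower number from compound 2 to compound 3 (2.61 log units; beyond the scatter), a large step well beyond the scatter. The earlier pair differed in several places at once, whereas this pair keeps everything else in compound 2, so it ties a large gain in inhibition to the aromatic group on this sulfur, whose other neighbour is a saturated chain carbon. Nothing shown here explains why the step is so large.

The swap removes the methyl groups and brings in the nitrile together, so the compounds shown cannot say which of the two accounts for the step, or whether both contribute. As far as these compounds go, it also remains open where a plain phenyl or a 2,4,6-trimethylphenyl-free 4-methylphenyl on the same sulfur would fall relative to compound 2 and compound 3, and whether a carboxylic acid or an amide in place of the nitrile would hold the stronger inhibition seen with compound 3.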